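Two Limits and an Untested Bromophenyl Analogue

The source may hold more compounds than are shown below. What is called first, only, known or untested is meant among the compounds shown, and "the series" means these compounds.

Compound 2, `C=CCSc1nnc(-c2cc(OC)c(OC)c(OC)c2)n1N1C(=O)c2ccccc2C1=O`, was examined in a functional assay on PC-3M cells (Homo sapiens) for cytotoxicity, read by MTT assay, with a stated time of 48 h; a lower number here means a stronger inhibitor, a higher number a weaker inhibitor. In this assay compound 2 gives only a limit, > 200000 nM. Compound 1, `CCCc1nnc(SCC(=O)c2ccccc2)n1N1C(=O)c2ccccc2C1=O`, likewise returns only a limit in this assay, > 200000 nM. Among the compounds with values here, both values sit on (the limit of > 200000 nM in this assay, at which 2 of the 2 values shown sit), so compound 2 stands level with the one other measured compound. Compound 3, `COc1cc(-c2nnc(SCC(=O)c3ccc(Br)cc3)n2N2C(=O)c3ccccc3C2=O)cc(OC)c1OC`, differs from compound 2 by (4-bromophenyl)carbonyl in place of vinyl on a saturated chain carbon bound to a sulfur. Within the data shown here, no measured step between compounds exists here. With both known values at the limit, the expected shift is an at least 1.3-fold lower number from compound 2 to compound 3 (0.12 log units; that floor lies within the scatter), nothing beyond the scatter. Compound 3 is estimated at 150000 nM, within 30000 nM to 400000 nM, and may again come back as a limit.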

Compound 3, half-maximal inhibitory concentration: 22600 nM
Compound 3: middle estimate off by 6.6-fold (0.82 log units), on the high side; measured number outside the range, below it.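

In this assay, the place on a saturated chain carbon bound to a sulfur now proves responsive: putting (4-bromophenyl)carbonyl in place of vinyl gives an at least 8.8-fold lower number from compound 2 to compound 3 (0.94 log units; beyond the scatter). Compound 3 thus supplies a measured number where the earlier compounds offered only a limit: the limit of > 200000 nM in this assay, at which 2 of the 3 values shown sit.

The compounds shown do not separate the share of the bromine from that of the phenyl ring or the carbonyl, which enter together. On these data alone, what a chlorine, an amine or a carboxylic acid in place of the bromine would give also remains open.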